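A few compounds are considered here, and "the series" means these few. Any claim that something is new, unique, unknown or untested is made for them only; others in the source may bear on it.

Compound 3 `COc1ccc(CCCCCCCCOc2ccc(C[S+]([O-])c3cccc(N)c3)nc2/C=C/C(=O)O)cc1` carries an amino group and gives 4.7 nM in an assay for binding affinity to leukotriene B4 receptor 1 (Homo sapiens) (a higher number here means a weaker inhibitor, a lower number a stronger inhibitor), the lowest of the three numbers measured; the nearest is compound 1 `COc1ccc(CCCCCCCCOc2ccc(C[S+]([O-])c3cccc(NS(=O)(=O)c4ccccc4)c3)nc2/C=C/C(=O)O)cc1` with 147 nM, and compound 2 `COc1ccc(CCCCCCCCOc2ccc(C[S+]([O-])c3cccc(CS(=O)(=O)C(F)(F)F)c3)nc2/C=C/C(=O)O)cc1` gives 225 nM. Compound 4 `COc1ccc(CCCCCCCCOc2ccc(C[S+]([O-])c3cccc(OC)c3)nc2/C=C/C(=O)O)cc1` has not been measured; it differs from compound 3 by methoxy in place of amino on an aromatic carbon. The steps that touch this position are a 31-fold lower number from compound 1 to compound 3 (1.50 log units; beyond the scatter) and a 48-fold lower number from compound 2 to compound 3 (1.68 log units; beyond the scatter), each swapping a larger group for amino with a large fall in the number. Neither tests a methoxy group directly, so the bearing is loose. Because compound 3 sits lowest at 4.7 nM and its amino group is now removed, a moderate rise is expected, namely a 5.3-fold higher number from compound 3 to compound 4 (0.73 log units; beyond the scatter). Compound 4 is therefore estimated at 25 nM, with a likely range from 6 nM to 110 nM.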

Compound 4, inhibition constant: 232 nM
Estimate against measurement, compound 4: 9.3-fold (0.97 log units) below; the whole stated range lies below it.
By their numbers in this assay, from the lowest: compound 3; then compounds 1, 2 and 4 (each within the scatter of the next).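

In this assay, methoxy in place of amino gives a 49-fold higher number from compound 3 to compound 4 (1.69 log units; beyond the scatter), a large step for so small an exchange. Methoxy, though small, lands level with the two much larger groups, with a 1.0-fold higher number from compound 2 to compound 4 (0.01 log units; within the scatter) and a 1.6-fold higher number from compound 1 to compound 4 (0.20 log units; within the scatter), so among these four compounds only compound 3, with its amino group, stands apart. Nothing available here explains what sets the amino group apart.

The compounds shown leave open whether a hydroxyl group or a methylamino group at this place would stay close to compound 3 or fall in with the other three.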